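A few compounds are considered here, and "the series" means these few. Any claim that something is new, unique, unknown or untested is made for them only; others in the source may bear on it.

Working notes on the series. Of the compounds shown here, two have been measured in an assay on cells for inhibition of cytochrome P450 11B2, mitochondrial (Homo sapiens), read by HTRF; on this read-out higher numbers stand for weaker inhibition and lower numbers for stronger inhibition. Compound 1, `CC1(C)c2cc(Cl)ccc2C(=O)N1c1cncc(OC2CN(C(=O)c3ncccc3Cl)C2)c1`, gives 5 nM in this assay. Compound 2, `CC(=O)N[C@@H]1CCCc2c1cncc2N1CCc2cc(Cl)ccc2C1=O`, gives 54 nM in this assay, the higher of the two numbers; its nearest neighbour is compound 1, whose number is lower by a gap that lies beyond the usual scatter of repeated measurements. Among the compounds with values here, no single-point step between the two measured compounds is available, since compound 1 and compound 2 differ in more than one place, so the two values are taken only as they stand.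

Compound 3, `CCC(=O)N[C@@H]1CCCc2c1cncc2N1CCc2cc(Cl)ccc2C1=O`, is not yet measured. It departs from compound 2 by one change: methyl in place of hydrogen on a saturated chain carbon bound to a carbonyl carbon. The acetamido group of compound 2 thus becomes a propanoylamino group in compound 3.

With no measured step of this kind in the series, the expectation is a step of a 1.1-fold lower number from compound 2 to compound 3 (0.03 log units; within the scatter) in this assay, which is taken to lie within the usual scatter rather than beyond it. On that basis, compound 3 is expected to give about 50 nM in this assay, estimated to fall between 18 nM and 150 nM.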

Compound 3, half-maximal inhibitory concentration: 119 nM
Compound 3: the middle estimate sits 2.4-fold (0.38 log units) below what was measured; low and high end bracket the measured number.
By their numbers in this assay, from the lowest: compound 1; then compound 2; then compound 3.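

Within the data shown here, the only single-change step so far is a 2.2-fold higher number from compound 2 to compound 3 (0.34 log units; beyond the scatter) in this assay, so on this read-out the change from acetamido to propanoylamino moves toward weaker inhibition, by a modest amount. Among these compounds, compound 1 and compound 2 differ in more than one place and could not show this; the new step is the first direct reading at this saturated chain carbon bound to a carbonyl carbon, and it shows that one added methyl there is enough to shift the number beyond the usual scatter. Nothing at hand accounts for the direction or size of this step.

On these data alone, with a single step at this position, no trend along the chain can be claimed, and it remains open whether a longer chain such as butanoylamino would continue the same direction or whether a branched isopropyl group or a cyclopropyl ring would depart from it. Also open, as far as these compounds go, is how a chain carrying an amine or a carboxylic acid, or a hydroxyl group in place of the added methyl, would read in this assay.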